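Swapping the Amide Tail for a Dichlorophenoxy Group

This account rests on a few compounds, and the source may have more. Where it says the series, first, only, none or still open, it means among the compounds named here.

Measured compounds in an assay on HEK293 cells for displacement of a labelled ligand from Melanocortin receptor 4 (Homo sapiens); on this read-out lower numbers stand for stronger inhibition and higher numbers for weaker inhibition:
compound 1 `CC(C)C[C@H](N)c1cc(C(F)(F)F)ccc1N1CCN(C(=O)C(C)Cc2ccc(Cl)c(Cl)c2)CC1` gives 120 nM; 1600 nM (2 entries)
compound 2 `Cc1ccc(OCC(=O)N2CCN(c3ccc(C(F)(F)F)cc3[C@@H](N)CC(C)C)CC2)cc1` gives 4400 nM
compound 3 `CC(C)C[C@H](N)c1cc(C(F)(F)F)ccc1N1CCN(C(=O)CCNC2CCCCC2)CC1` gives 4800 nM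

Compound 3 stands at the highest of the two single numbers; its nearest neighbour is compound 2, and the step of a 1.1-fold higher number from compound 2 to compound 3 (0.04 log units; within the scatter) lies within the scatter. Compound 1 carries two entries the several entries of compound 1 in this assay, 120 nM; 1600 nM (2 entries) that differ between themselves, so no single number is given for it. Compound 4 `CC(C)C[C@H](N)c1cc(C(F)(F)F)ccc1N1CCN(C(=O)COc2cccc(Cl)c2Cl)CC1` arises from compound 3 by 2,3-dichlorophenoxy in place of (cyclohexylamino)methyl on a saturated chain carbon bound to a carbonyl carbon. Among the measured compounds shown here, the only measured step, a 1.1-fold higher number from compound 2 to compound 3 (0.04 log units; within the scatter), exchanged a phenoxy group for the cyclohexylaminomethyl group without effect beyond the scatter, so returning to a phenoxy group, now chlorinated, is not expected by itself to move the number far. Compound 1, which also bears two chlorines on its aromatic ring, shows the lower numbers of the set, though no one-step comparison links it to compound 3 or compound 4. Compound 4 is therefore expected near 1500 nM, with a range from 300 nM to 7000 nM. This expected change corresponds to a 3.2-fold lower number from compound 3 to compound 4 (0.51 log units; beyond the scatter).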

Compound 4, inhibition constant: 2500 nM
Compound 4: middle estimate off by 1.7-fold (0.22 log units), on the low side, and the stated range covers the measured number.
By their numbers in this assay, from the lowest: compounds 4, 2 and 3 (each within the scatter of the next).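

In this assay, the place on a saturated chain carbon bound to a carbonyl carbon now holds a third group with no move beyond the scatter (a 1.9-fold lower number from compound 3 to compound 4 (0.28 log units; within the scatter)). Within the phenoxy series, 2,3-dichlorophenyl in place of 4-methylphenyl also stays within the scatter (a 1.8-fold lower number from compound 2 to compound 4 (0.25 log units; within the scatter)). Nothing measured here explains why these groups read alike.

From the compounds shown here alone, whether a carboxylic acid or a longer chain at this place would read differently remains open. How compound 1 relates to these compounds also stays unsettled, as its entries disagree: the several entries of compound 1 in this assay, 120 nM; 1600 nM (2 entries)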